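A few compounds are considered here, and "the series" means these few. Any claim that something is new, unique, unknown or untested is made for them only; others in the source may bear on it.

Working notes on the series. Compound 1 `CCCCNc1nc(N)nc2c1CCN(C(C)=O)C2` and compound 2 `CCCCNc1nc(N)nc2c1CN(C(=O)c1ccccc1)CC2` share a core and differ in the group on the amine nitrogen in the ring. In an assay on HEK293 cells for agonist activity at Toll-like receptor 8 (Homo sapiens), read by a luciferase reporter, with a stated time of 6 h (a lower number here means that less compound is needed, a higher number that more compound is needed for the effect), compound 1 gives 0.4 uM, while in this assay compound 2 gives 1.4 uM. Compound 2 therefore stands highest of the two numbers recorded so far, and the gap to compound 1 is beyond the usual scatter of repeated measurements. Among the compounds with values here, no single-point step between measured compounds is available for this series.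

Compound 3 `CCCCNc1nc(N)nc2c1CN(Cc1cccnc1)CC2` has not yet been measured. It differs from compound 2 as follows ((pyridin-3-yl)methyl in place of benzoyl on an amine nitrogen in a ring). Within the data shown here, nothing measured so far shows how a (pyridin-3-yl)methyl group on this amine nitrogen in a ring compares with a benzoyl group, so the expectation rests only on compound 2 as the nearest neighbour.

The step from compound 2 to compound 3 is expected to be small, a 1.4-fold lower number from compound 2 to compound 3 (0.15 log units; within the scatter), in the direction of a slightly lower number but not clearly beyond the scatter. In this assay compound 3 is thus estimated at 1 uM, with a range from 0.3 uM to 4 uM.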

Compound 3, minimum effective concentration: 0.13 uM
The estimate for compound 3 lay 7.7-fold (0.89 log units) above the measured number, and the stated range ends above it.
By their numbers in this assay, from the lowest: compound 3; then compound 1; then compound 2.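

In this assay, the change on the amine nitrogen in a ring gives the series its first single-point step, and that step is large: an 11-fold lower number from compound 2 to compound 3 (1.03 log units; beyond the scatter). Within the data shown here, the group at this position therefore matters for the minimum effective concentration, which the earlier compounds could not show because they offered no single-point step. The two groups have the same counts of hydrogen-bond donors and acceptors, so those counts do not distinguish them here, and no measurement at hand bears on why the step is this large.

The step replaces the benzoyl carbonyl with a methylene link and a ring carbon with a ring nitrogen in one move, so the compounds shown do not separate these two changes; a phenylmethyl group on the same nitrogen would do so. They also leave open whether the placement of the ring nitrogen matters, as a (pyridin-4-yl)methyl or (pyridin-2-yl)methyl group would test, and whether a longer chain between the aromatic ring and the amine nitrogen would be tolerated.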